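Removing the pyrazolylamino group from compound 2

This account rests on a few compounds, and the source may have more. Where it says the series, first, only, none or still open, it means among the compounds named here.

Of the compounds shown here, three sharing one core have been measured in an assay on isolated protein for binding affinity to Leucine-rich repeat serine/threonine-protein kinase 2 variant G2019S (Homo sapiens), read by TR-FRET and LanthaScreen, with a stated time of 2 h; on this read-out lower numbers stand for stronger inhibition and higher numbers for weaker inhibition. Compound 1 `Cn1c(N2CCCC2)c(C#N)c2c(N)ncnc21` gives 125 nM, compound 3 `C[C@H]1CCCN1c1c(C#N)c2c(N)ncnc2n1C` gives 212 nM, and the step of a 1.7-fold higher number from compound 1 to compound 3 (0.23 log units; within the scatter) stays within the scatter. Compound 2 `Cc1cn(C)nc1Nc1cc2c(c(N)n1)c(C#N)c(N1CCC[C@H]1C)n2C` gives 75 nM, the lowest number of the three; its gap to compound 1 lies within the scatter, its gap to compound 3 beyond it. Compound 4 `C[C@@H]1CCCN1c1c(C#N)c2c(N)nccc2n1C` differs from compound 2 by hydrogen in place of (1,4-dimethyl-1H-pyrazol-3-yl)amino on an aromatic carbon. Going by the values given here, no measured step removes this group, so no direct guide exists; compound 3, which also lacks it, gives the highest number. Compound 4 is therefore expected to bind more weakly, with a step of a 4.0-fold higher number from compound 2 to compound 4 (0.60 log units; beyond the scatter) and an estimated 300 nM in this assay, spanning 100 nM to 900 nM.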

Compound 4, inhibition constant: 2 nM
Compound 4: middle estimate off by 150-fold (2.18 log units), on the high side; measured number outside the range, below it.
By their numbers in this assay, from the lowest: compound 4; then compounds 2, 1 and 3 (each within the scatter of the next, the first and the last beyond it).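

In this assay, hydrogen in place of (1,4-dimethyl-1H-pyrazol-3-yl)amino on this aromatic carbon gives a 38-fold lower number from compound 2 to compound 4 (1.57 log units; beyond the scatter). The pyrazolylamino group is therefore not needed for strong binding in this series, and removing it helps rather than harms, though this rests on a single pair of compounds. Nothing available explains the size of this step.

Still open, as far as these compounds go, is whether a small group on this carbon, such as methyl or methoxy, would give a number close to that of compound 4 or of compound 2.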